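Amide Swap on an Inactive Core: Phenyl to Pyridyl

The compounds below may be only part of what the source reports. "The series", "measured", "known", "first", "only" and "open" are said of these compounds alone.

Compound 1 `Cn1cc(-c2cnc3ccnc(NC(=O)C4CC4)c3c2)cn1`: > 50000 nM
Compound 2 `Cn1cc(-c2cnc3ccnc(NC(=O)c4ccc(F)cc4)c3c2)cn1`: > 50000 nM

In a functional assay on HeLa cells (Homo sapiens) for antiproliferative activity, read by MTT assay, with a stated time of 48 h (on this read-out lower numbers stand for stronger inhibition and higher numbers for weaker inhibition), compound 1 gives only a limit, > 50000 nM. Compound 2 likewise reaches only a limit in this assay, > 50000 nM. Going by the values given here, the single measured step, a step that the two limits leave unreadable from compound 1 to compound 2, cannot be read because both of its ends sit at the limit of > 50000 nM in this assay, at which 2 of the 2 values shown sit. Compound 3 `Cn1cc(-c2cnc3ccnc(NC(=O)c4cccnc4)c3c2)cn1` differs from compound 2 by pyridin-3-yl in place of 4-fluorophenyl on a carbonyl carbon. No readable measured step bears on this change, so the available numbers give no ground to expect anything beyond a limit. Compound 3 is therefore expected at 50000 nM, with a range from 15000 nM to 50000 nM, which means an expected step of a number no higher from compound 2 to compound 3 (the limit leaves the size open).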

Compound 3, half-maximal inhibitory concentration: > 50000 nM
Compound 3 gave a limit, no number; the forecaster's own chance of this, stated with the estimate: 85%; the middle value sits exactly at the limit.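

Compound 3, like compound 1 and compound 2, gives only a limit in this assay, so no step among the three can be read: the limit of > 50000 nM in this assay, at which 3 of the 3 values shown sit.

The compounds shown leave open how cyclopropyl, 4-fluorophenyl and pyridin-3-yl on the carbonyl carbon compare in this assay.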